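The source may hold more compounds than are shown below. What is called first, only, known or untested is meant among the compounds shown, and "the series" means these compounds.

Compound 1 `COc1ccc(Oc2nc(Nc3ccc(C#N)cc3)nc3ccccc23)cc1`: 340000 nM
Compound 2 `N#Cc1ccc(Nc2nc(Oc3ccc(F)cc3)c3ccccc3n2)cc1`: > 351000 nM (a limit of the assay, not a number)
Compound 3 `Cc1cccc(C)c1Oc1nc(Nc2ccc(C#N)cc2)nc2ccccc12`: 35000 nM

In an ADME assay on MT4 cells (Homo sapiens) for cytotoxicity, read by MTT assay, with a stated time of 4 days (a lower number here means that less compound is tolerated, a higher number that more compound is tolerated), compound 1 holds the higher of the two exact numbers, and compound 3 holds the lower. Compound 4 `Cc1cc(Br)cc(Br)c1Oc1nc(Nc2ccc(C#N)cc2)nc2ccccc12` has not been measured yet. It carries 2,4-dibromo-6-methylphenyl in place of 4-methoxyphenyl on an oxygen on an aromatic ring.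

Changing to 4-fluorophenyl gave an at least 1.0-fold higher number from compound 1 to compound 2 (0.01 log units; that floor lies within the scatter), which offers little guidance. The closer precedent is compound 3, whose 2,6-dimethylphenyl group also carries a methyl and gave a 9.7-fold lower number from compound 1 to compound 3 (0.99 log units; beyond the scatter), and likewise an at least 10-fold lower number from compound 2 to compound 3 (1.00 log units; beyond the scatter). A similar drop is therefore expected in this assay. The estimated step is a 14-fold lower number from compound 1 to compound 4 (1.13 log units; beyond the scatter). Compound 4 is expected near 25000 nM, within an estimated range of 6000 nM to 90000 nM.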

Compound 4, half-maximal cytotoxic concentration: 150000 nM
The estimate for compound 4 lay 6.0-fold (0.78 log units) below the measured number, outside the stated range (above it).
By their numbers in this assay, from the lowest: compound 3; then compound 4; then compound 1. At a limit, above all of these: compound 2.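

In this assay, going by these compounds alone, a methyl group on this ring does not by itself bring a drop as large as the one seen with compound 3: the 2,4-dibromo-6-methylphenyl group gives a 2.3-fold lower number from compound 1 to compound 4 (0.36 log units; beyond the scatter). Placing it on the oxygen instead of 2,6-dimethylphenyl gives a 4.3-fold higher number from compound 3 to compound 4 (0.63 log units; beyond the scatter), so the group's other substituents matter as well as its methyl. The remaining step, an at least 2.3-fold lower number from compound 2 to compound 4 (0.36 log units; beyond the scatter), is only a floor: the limit of > 351000 nM in this assay, at which 1 of the 4 values shown sits.

On these data alone, whether one bromine alone would give the same number stays open. So does the outcome with an amine or a carboxylic acid on this ring.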